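This account rests on a few compounds, and the source may have more. Where it says the series, first, only, none or still open, it means among the compounds named here.

Values so far in a physicochemical assay for solubility, in phosphate buffer, measured as kinetic solubility, with a stated time of 24 h, at pH 6.5; a lower number here means a less soluble compound, a higher number a more soluble compound
Compound 1 `Cc1cc(=O)[nH]c(-c2cc(Oc3ccc(S(C)(=O)=O)cc3)cc(OC(C)C)c2)n1` (15000 nM)
Compound 2 `CC(C)Oc1cc(Oc2cnc(C(=O)N(C)C)cn2)cc(-c2nccc(=O)[nH]2)c1` (373000 nM)
Compound 3 `C[C@@H](CO)Oc1cc(Oc2cnc(C(=O)N(C)C)nc2)cc(-c2nccc(=O)[nH]2)c1` (339000 nM)

Compound 2 shares the top of this range with compound 3, the two lying within the scatter of each other, while compound 1 lies beyond the scatter below compound 2. Compound 4 `COC[C@H](C)Oc1cc(Oc2cnc(C(=O)N(C)C)cn2)cc(-c2nccc(=O)[nH]2)c1` is compound 2 with one change (methoxy in place of hydrogen on a saturated chain carbon, two bonds along the chain from an oxygen on an aromatic ring): methoxy in place of hydrogen on a saturated chain carbon, two bonds along the chain from an oxygen on an aromatic ring. Isopropoxy thus becomes 1-(methoxymethyl)ethoxy. Among the measured compounds shown here, no measured pair shows this change alone. Compound 3 carries a different chain, among other differences, and its value (339000 nM) stays close to that of compound 2. In this assay the estimated step of a 1.1-fold lower number from compound 2 to compound 4 (0.05 log units; within the scatter) is expected to stay within the scatter, with no clear direction. The expected value for compound 4 is 330000 nM and the estimated range runs from 150000 nM to 600000 nM as a guide.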

Compound 4, solubility: 728000 nM
Compound 4: middle estimate off by 2.2-fold (0.34 log units), on the low side; measured number outside the range, above it.
By their numbers in this assay, from the lowest: compound 1; then compounds 3, 2 and 4 (each within the scatter of the next, the first and the last beyond it).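

In this assay, among the compounds shown here, this pair isolates the methoxy change for the first time: the step is a 2.0-fold higher number from compound 2 to compound 4 (0.29 log units; within the scatter), so isopropoxy and 1-(methoxymethyl)ethoxy cannot be told apart here. At this saturated chain carbon, then, the extra methoxy comes with no shift beyond the usual scatter. Nothing measured here offers an explanation for this result. This is a single pair on a single core, so it cannot show whether the result holds elsewhere. Going by these compounds, whether an amine, a carboxylic acid or a longer chain at this carbon would also stay within the scatter remains open.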